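The compounds below may be only part of what the source reports. "The series", "measured", "known", "first", "only" and "open" are said of these compounds alone.

Measured so far in an assay on isolated protein with Bile acid receptor (Homo sapiens) as the target; a higher number here means that more compound is needed for the effect, a lower number that less compound is needed:
Compound 1 `COC(=O)/C=C/c1cccc(N(Cc2ccccc2Br)C(=O)C2CCCCC2)c1` gives > 1000 nM, a limit of this assay.
Compound 2 `COC(=O)/C=C/c1cccc(N(Cc2ccc(Br)cc2)C(=O)C2CCCCC2)c1` gives > 1000 nM, also a limit.
Compound 3 `COC(=O)/C=C/c1ccc(CN(C(=O)C2CCCCC2)c2cccc(/C=C/C(=O)OC)c2)cc1` gives > 1000 nM, again a limit.

Compound 3 thus stands only at a limit in this assay. All three values shown sit at the same limit (the limit of > 1000 nM in this assay, at which 3 of the 3 values shown sit). Compound 4 `COC/C=C/c1ccc(CN(C(=O)C2CCCCC2)c2cccc(/C=C/C(=O)OC)c2)cc1` differs from compound 3 by methoxymethyl in place of methoxycarbonyl on a double-bonded chain carbon bound to a double-bonded chain carbon. The measured steps a step that the two limits leave unreadable from compound 1 to compound 2 and a step that the two limits leave unreadable from compound 2 to compound 3 are both unreadable, so they give no size to carry over, and neither concerns the change made here. No step beyond the scatter is therefore expected in this assay, in either direction, and compound 4 is expected most likely to remain at the limit. Estimated for compound 4: 3000 nM, range 700 nM to 20000 nM, meaning an expected step that the limit leaves unreadable from compound 3 to compound 4.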

Compound 4, half-maximal effective concentration: 233 nM
Compound 4: middle estimate off by 13-fold (1.11 log units), on the high side, outside the stated range (below it).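

In this assay, among these compounds, methoxymethyl in place of methoxycarbonyl on this double-bonded chain carbon gives the first readable step (an at least 4.2-fold lower number from compound 3 to compound 4 (0.63 log units; beyond the scatter)). Among the compounds shown here, compound 4 also stands clear of both bromo compounds (an at least 4.2-fold lower number from compound 2 to compound 4 (0.63 log units; beyond the scatter); an at least 4.2-fold lower number from compound 1 to compound 4 (0.63 log units; beyond the scatter)), whereas the earlier steps cannot be read. Each new step is only a minimum, since its starting compound sits at a limit: the limit of > 1000 nM in this assay, at which 3 of the 4 values shown sit.

From the compounds shown here alone, whether a carboxylic acid, an amine or a longer chain at this position would keep or extend the step remains open. Also open, going by these compounds, is whether the same change at the other methoxycarbonyl group of compound 4 would have a similar effect.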